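Switching the amine substituent on a shared indole-piperidine core

A few compounds are considered here, and "the series" means these few. Any claim that something is new, unique, unknown or untested is made for them only; others in the source may bear on it.

Measured so far in an assay on CHO cells for displacement of a labelled ligand from 5-hydroxytryptamine receptor 1B (Homo sapiens); on this read-out higher numbers stand for weaker inhibition and lower numbers for stronger inhibition:
compound 1 `C[C@@H](NCC1CCN(CCCc2c[nH]c3ccc(-n4cnnc4)cc23)CC1)c1ccccc1`: 14 nM
compound 2 `CN(Cc1cccs1)C1CCN(CCCc2c[nH]c3ccc(-n4cnnc4)cc23)CC1`: 140 nM
compound 3 `O[C@@H]1Cc2ccccc2[C@H]1NC1CCN(CCCc2c[nH]c3ccc(-n4cnnc4)cc23)CC1`: 210 nM

Compound 3 gives the highest number of the three in this assay; compound 2 sits within the scatter of it, while compound 1 is clearly separated, as the step of a 15-fold higher number from compound 1 to compound 3 (1.18 log units; beyond the scatter) shows. The other measured steps are a 10-fold higher number from compound 1 to compound 2 (1.00 log units; beyond the scatter) and a 1.5-fold higher number from compound 2 to compound 3 (0.18 log units; within the scatter).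

Compound 4 `CC(=O)Nc1ccc(CNC2CCN(CCCc3c[nH]c4ccc(-n5cnnc5)cc34)CC2)cc1` differs from compound 3 in one place: 4-acetamidobenzyl in place of 2-hydroxy-2,3-dihydro-1H-inden-1-yl on an amine nitrogen. For the measured compounds named here, no measured step has this exact change, but the two steps that start from compound 1 show that the group on this amine nitrogen can move the number by a modest to large amount, and the step from compound 2 to compound 3 shows that two such groups can also sit within the scatter of each other.

The 4-acetamidobenzyl group keeps one aromatic ring on a single linking carbon, as in compound 1, which gave 14 nM. Compound 4 is therefore expected to come in somewhat lower than compound 3, a step of a 2.6-fold lower number from compound 3 to compound 4 (0.42 log units; beyond the scatter), with an estimate of 80 nM and a range from 25 nM to 250 nM.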

Compound 4, half-maximal inhibitory concentration: 45 nM
Compound 4: middle estimate off by 1.8-fold (0.25 log units), on the high side; the measured number falls inside the stated range.
By their numbers in this assay, from the lowest: compound 1; then compound 4; then compounds 2 and 3 (each within the scatter of the next).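

For the compounds shown here, compound 4 gives the first step in which only the group on this secondary amine nitrogen changes, with the nitrogen still on the saturated ring carbon: in this assay, a 4.7-fold lower number from compound 3 to compound 4 (0.67 log units; beyond the scatter), a change beyond the scatter. The earlier steps shown here from compound 1 and compound 2 also altered what else surrounds this nitrogen, so this step shows more directly that the group on it can shift the number on its own. The exchange replaces the fused 2-hydroxy-2,3-dihydro-1H-inden-1-yl, with its two defined stereocentres, by an open 4-acetamidobenzyl, and nothing available accounts for the shift.

The compounds shown leave open how much of the step belongs to the acetamido group and how much to the benzyl frame. A plain benzyl or a 4-aminobenzyl group on the same nitrogen would separate the two.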